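Chain length and growth inhibition across four homologues

The source may hold more compounds than are shown below. What is called first, only, known or untested is meant among the compounds shown, and "the series" means these compounds.

Compound 1 `CCc1cc2ccccc2nc1-c1cc(-c2ccccc2)no1` gives > 100000 nM, a limit of the assay.
Compound 2 `CCCc1cc2ccccc2nc1-c1cc(-c2ccccc2)no1` gives 48900 nM.
Compound 3 `CCCCc1cc2ccccc2nc1-c1cc(-c2ccccc2)no1` gives > 100000 nM, again a limit.

In a functional assay on COLO 205 cells (Homo sapiens) for inhibition, read by MTT assay, with a stated time of 24 h (on this read-out lower numbers stand for stronger inhibition and higher numbers for weaker inhibition), compound 3 therefore stands at a limit, not at a number. Two of the three values shown sit at the limit of > 100000 nM in this assay, at which 2 of the 3 values shown sit, and only compound 2 gives a readable number. Compound 4 `CCCCCc1cc2ccccc2nc1-c1cc(-c2ccccc2)no1` differs from compound 3 by methyl in place of hydrogen on a saturated chain carbon, four bonds along the chain from an aromatic carbon. The earlier steps shown here along the same chain point in opposite directions: an at least 2.0-fold lower number from compound 1 to compound 2 (0.31 log units; beyond the scatter), then an at least 2.0-fold higher number from compound 2 to compound 3 (0.31 log units; beyond the scatter), while a step that the two limits leave unreadable from compound 1 to compound 3. No consistent drift with chain length emerges from these three compounds. Since compound 3 is already at a limit, compound 4 is expected to stay near it, with a step that the limit leaves unreadable from compound 3 to compound 4 as the expected step. The estimate for compound 4 is 150000 nM, within a range of 40000 nM to 600000 nM, most likely reported only as a limit.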

Compound 4, half-maximal inhibitory concentration: > 100000 nM
Compound 4 was reported as a limit (the forecaster's own chance of this, stated with the estimate: 75%); the middle value does not contradict the limit.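

In this assay compound 4 gives > 100000 nM as a limit of the assay, so methyl in place of hydrogen four bonds along the chain from an aromatic carbon yields no readable number. Among these compounds, the one readable step is an at least 2.0-fold higher number from compound 2 to compound 4 (0.31 log units; beyond the scatter) and the steps to compound 4 from compound 1 and compound 3 cannot be read. Compound 2 remains the only one of the four with a readable number: the limit of > 100000 nM in this assay, at which 3 of the 4 values shown sit. On these data alone, whether a longer chain stays at this limit remains open, as does whether an amine or a carboxylic acid in place of the chain would give a readable number.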